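The source may hold more compounds than are shown below. What is called first, only, known or untested is meant among the compounds shown, and "the series" means these compounds.

Measured in a functional assay on the whole organism with Rattus norvegicus as the target; a lower number here means that less compound is needed, a higher number that more compound is needed for the effect:
compound 1 `CCN(CCNC(=O)c1cc(Cl)c(N)cc1OC)Cc1ccccc1`: 0.31 mg/kg
compound 2 `CCN(CCNC(=O)c1cc(Cl)c(N)cc1OC)Cc1ccccc1OC`: 10 mg/kg

Among the compounds with values here, compound 2 holds the higher of the two numbers, and compound 1 is its only neighbour. Compound 3 `CCN(CCNC(=O)c1cc(Cl)c(N)cc1OC)Cc1cccc(Cl)c1` is to be measured next, with this change from compound 2: 3-chlorophenyl in place of 2-methoxyphenyl on a saturated chain carbon bound to an amine nitrogen. In words, 3-chlorophenyl stands in place of 2-methoxyphenyl on a saturated chain carbon bound to an amine nitrogen.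

Within the data shown here, one measured step bears on this: a 32-fold higher number from compound 1 to compound 2 (1.51 log units; beyond the scatter), large and beyond the scatter, with methoxy in place of hydrogen on an aromatic carbon. Compound 3 no longer carries that methoxy, so much of that step is expected to be recovered. Among the measured compounds shown here, no measured step covers the chlorine, so full recovery is not assumed and the range stays wide. The expected change in this assay is a 10-fold lower number from compound 2 to compound 3 (1.00 log units; beyond the scatter), a large step. For compound 3 the estimated value is 1 mg/kg, with an expected range of 0.2 mg/kg to 6 mg/kg.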

Compound 3, dose for half-maximal effect: 0.58 mg/kg
Estimate against measurement, compound 3: 1.7-fold (0.24 log units) above, within the range that was stated.
By their numbers in this assay, from the lowest: compounds 1 and 3 (each within the scatter of the next); then compound 2.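

In this assay the exchange of 2-methoxyphenyl for 3-chlorophenyl on a saturated chain carbon bound to an amine nitrogen gives a 17-fold lower number from compound 2 to compound 3 (1.24 log units; beyond the scatter) and shows that a substituted phenyl group at this position can keep a low number, which compound 2 alone did not suggest. Chloro in place of hydrogen on an aromatic carbon gives a 1.9-fold higher number from compound 1 to compound 3 (0.27 log units; within the scatter) and leaves compound 1 and compound 3 without an order, so here this substituent costs nothing that can be read. No supporting measurement bears on why the two substituted phenyl groups part so widely.

The step from compound 2 to compound 3 changes both the substituent and its ring position, so 2-chlorophenyl and 3-methoxyphenyl would be needed to separate the two. Going by these compounds, how a phenyl group carrying an amine or a carboxylic acid would read in this assay also stays open.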